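The source may report more compounds than this note shows. Statements on the series, on what has been measured and on what is new or still open speak of the compounds shown alone.

In a functional assay on MDA-MB-231 cells (Homo sapiens) for antiproliferative activity, read by MTT assay, with a stated time of 48 h (on this read-out higher numbers stand for weaker inhibition and lower numbers for stronger inhibition), compound 1 `C=CS(=O)(=O)N1CCN(c2ncnc3sc(-c4ccc(OC)nc4)cc23)CC1` gives 9270 nM and compound 2 `CN1CCN(c2ccc(-c3cc4c(N5CCN(C(=O)Nc6ccccc6)CC5)ncnc4s3)cc2)CC1` gives 7590 nM. Of these two numbers compound 2 sits at the low end, yet its distance from compound 1 is within the usual scatter of repeated measurements, so the two cannot be told apart on this read-out.

Compound 3 `CN1CCN(c2ccc(-c3cc4c(N5CCN(C(=O)Nc6cc(C(F)(F)F)ccc6F)CC5)ncnc4s3)cc2)CC1` keeps the whole of compound 2 except for one change: 2-fluoro-5-(trifluoromethyl)phenyl in place of phenyl on an amide-type nitrogen. For the measured compounds named here, no step between measured compounds shows what such a change does here, so there is nothing to lean on beyond compound 2 itself. The expected step of a 1.3-fold lower number from compound 2 to compound 3 (0.10 log units; within the scatter) is therefore small, and most likely it stays within the scatter, in either direction. On that basis compound 3 is estimated to give 6000 nM in this assay, with a plausible range from 2000 nM to 18000 nM.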

Compound 3, half-maximal inhibitory concentration: 9090 nM
Compound 3: middle estimate off by 1.5-fold (0.18 log units), on the low side; measured number inside the range.
By their numbers in this assay, from the lowest: compounds 2, 3 and 1 (each within the scatter of the next).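

In this assay, placing 2-fluoro-5-(trifluoromethyl)phenyl in place of phenyl on the amide-type nitrogen gives a 1.2-fold higher number from compound 2 to compound 3 (0.08 log units; within the scatter) and so leaves the two compounds indistinguishable on this read-out. This position therefore accepts a group of 11 heavy atoms, four of them fluorine, where a phenyl of 6 carbon atoms stood, with no change that can be told from the scatter. No measured property of either group is available to help explain this result.

On these data alone, the fluorine and the trifluoromethyl group enter together here, so the separate contribution of each remains unknown. As far as these compounds go, it also remains open whether a phenyl ring carrying an amine or a carboxylic acid, or a small methyl group in place of the ring, would shift the number beyond the scatter.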